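Thiophen-2-yl in place of 4-methoxyphenyl on a shared core

The source may report more compounds than this note shows. Statements on the series, on what has been measured and on what is new or still open speak of the compounds shown alone.

Of the compounds shown here, three built on one core have been tested in a functional assay on HCT-116 cells (Homo sapiens) for cytotoxicity, read by sulforhodamine B assay, with a stated time of 48 h; on this read-out lower numbers stand for stronger inhibition and higher numbers for weaker inhibition. Compound 1 `COc1cc(/C=C/C(=O)/C=C/c2cc(OC)c(OC)c(OC)c2)ccc1OCc1cn(CCCOc2cc(=O)oc3ccccc23)nn1` gives 8650 nM, compound 2 `COc1ccc(/C=C/C(=O)/C=C/c2ccc(OCc3cn(CCOc4cc(=O)oc5ccccc45)nn3)c(OC)c2)cc1` gives 9290 nM, and compound 3 `COc1ccc(/C=C/C(=O)/C=C/c2ccc(OCc3cn(CCCOc4cc(=O)oc5ccccc45)nn3)c(OC)c2)cc1OC` gives 11000 nM. Compound 2 stands second highest of the three numbers, within the scatter of both compound 1 and compound 3. Going by the values given here, the only single-point step measured, a 1.3-fold higher number from compound 1 to compound 3 (0.10 log units; within the scatter), also stays within the scatter. Compound 4 `COc1cc(/C=C/C(=O)/C=C/c2cccs2)ccc1OCc1cn(CCOc2cc(=O)oc3ccccc23)nn1` differs from compound 2 by thiophen-2-yl in place of 4-methoxyphenyl on a double-bonded chain carbon bound to a double-bonded chain carbon. Among the compounds with values here, no measured step involves a thiophen-2-yl group, so the change can be judged only against the narrow spread of the three values. The step is therefore expected to be a 1.0-fold lower number from compound 2 to compound 4 (0.01 log units; within the scatter), with no direction beyond the scatter. Compound 4 is estimated at 9000 nM, between 4500 nM and 18000 nM.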

Compound 4, half-maximal inhibitory concentration: 9290 nM
Compound 4: the middle estimate sits 1.0-fold (0.01 log units) below what was measured, and the stated range covers the measured number.
By their numbers in this assay, from the lowest: compounds 1, 2, 4 and 3 (each within the scatter of the next).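

Thiophen-2-yl in place of 4-methoxyphenyl gives no change at the digits printed from compound 2 to compound 4 (within the scatter) in this assay. Going by these compounds alone, this is the first measured step at this place, on a double-bonded chain carbon bound to a double-bonded chain carbon, and it shows that a five-membered aromatic ring with sulfur can stand for the six-membered carbon ring and its methoxy group without moving the number beyond the scatter. Nothing available here explains this result. As far as these compounds go, whether a ring carrying an amine or a carboxylic acid at this place would move the number stays open. So does whether thiophen-2-yl would behave alike in the other compounds of the shared core.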